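From compound 1 to compound 4: losing the hydroxycarbamoyl

The compounds below may be only part of what the source reports. "The series", "measured", "known", "first", "only" and "open" are said of these compounds alone.

Measured in a functional assay on HCT-116 cells (Homo sapiens) for inhibition, read by MTT assay, with a stated time of 72 h; on this read-out lower numbers stand for stronger inhibition and higher numbers for weaker inhibition:
compound 1 `Nc1nc2cc(-c3nn(CCCC(=O)NO)c4ncnc(N)c34)ccc2o1` gives 19600 nM
compound 2 `Nc1ncnc2c1c(-c1cnc3[nH]ccc3c1)nn2CCCCC(=O)NO` gives > 150000 nM, a limit
compound 3 `Nc1ncnc2c1c(-c1cnc3[nH]ccc3c1)nn2CCC(=O)NO` gives > 150000 nM, a limit

Going by the values given here, compound 1, at 19600 nM, is the only compound here with a readable number. Compound 2 and compound 3 share (the limit of > 150000 nM in this assay, at which 2 of the 3 values shown sit).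

Compound 4 `CNC(=O)CCCCCCCn1nc(-c2ccc3oc(N)nc3c2)c2c(N)ncnc21` keeps the core of compound 1 and ends its chain differently: 4-(methylcarbamoyl)butyl in place of hydroxycarbamoyl on a saturated chain carbon, three bonds along the chain from an aromatic nitrogen. Among the compounds with values here, all three measured compounds carry hydroxycarbamoyl, so the loss of that group has no measured precedent here. Within the data shown here, the only measured step on the chain, a step that the two limits leave unreadable from compound 2 to compound 3, gives no size and stands on a core other than that of compound 1.

With no readable step to draw on, the expectation starts from compound 1 at 19600 nM and leans towards weaker inhibition, with a wide margin. The expected step is a 2.0-fold higher number from compound 1 to compound 4 (0.31 log units; beyond the scatter), and its size is only loosely estimated. A result for compound 4 that is only a limit is also expected to be a real possibility. For compound 4 the estimated value is 40000 nM, with an expected range from 8000 nM to 150000 nM.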

Compound 4, half-maximal inhibitory concentration: 3150 nM
Compound 4: the middle estimate sits 13-fold (1.10 log units) above what was measured; the whole stated range lies above it.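

In this assay, the hydroxycarbamoyl is not required for a readable number on the core of compound 1: placing 4-(methylcarbamoyl)butyl on the saturated chain carbon, three bonds along the chain from an aromatic nitrogen, gives a 6.2-fold lower number from compound 1 to compound 4 (0.79 log units; beyond the scatter). Going by these compounds alone, this is the only readable step, and it shows that this position accepts a markedly longer chain with a methylcarbamoyl end while inhibition grows stronger, though the step remains modest. The chain series on the other core offers no comparison, since the values of compound 2 and compound 3 are limits and the step between them cannot be read: the limit of > 150000 nM in this assay, at which 2 of the 4 values shown sit.

Within the data shown here, the single step changes chain length and end group together, so the shares of the two cannot be separated; a hydroxycarbamoyl on the longer chain of compound 4, or a primary amide or carboxylic acid on the shorter chain of compound 1, would divide them. From the compounds shown here alone, whether 4-(methylcarbamoyl)butyl gives a readable number on the core of compound 2 also remains open.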